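Aromatic Substituent Changes in a 5-HT6 Binding Series

The source may report more compounds than this note shows. Statements on the series, on what has been measured and on what is new or still open speak of the compounds shown alone.

Of the compounds shown here, three sharing one core have been measured in an assay on HEK293 cells for displacement of a labelled ligand from 5-hydroxytryptamine receptor 6 (Homo sapiens), with a stated time of 60 min, tested at 1 uM, in the presence of a further agent that is not named here; on this read-out higher numbers stand for a stronger effect at the one concentration tested and lower numbers for a weaker effect. Compound 1 `COc1ccc(S(=O)(=O)NCCN2CCC(CCC(=O)c3cc(Cl)c(N)cc3OC)CC2)cc1Cl` gives 85%, compound 2 `COc1ccc(S(=O)(=O)NCCN2CCC(CCC(=O)c3cc(Cl)c(N)cc3OC)CC2)cc1` gives 52%, and compound 3 `COc1ccc(S(=O)(=O)NCCN2CCC(CCC(=O)c3cc(Cl)c(N)cc3OC)CC2)cc1OC` gives 58%. Compound 3 is the second highest of the three; it sits close to compound 2, the gap between them falling a number 6 percentage points higher from compound 2 to compound 3 (within the scatter), while it stands a number 27 percentage points lower from compound 1 to compound 3 (beyond the scatter). Compound 4 `COc1cc(N)c(Cl)cc1C(=O)CCC1CCN(CCNS(=O)(=O)c2ccc(OC)c(N3CCN(C)CC3)c2)CC1` differs from compound 3 by 4-methylpiperazin-1-yl in place of methoxy on an aromatic carbon. The measured steps at this aromatic carbon were a number 33 percentage points lower from compound 1 to compound 2 (beyond the scatter) and a number 27 percentage points lower from compound 1 to compound 3 (beyond the scatter), but none introduced a ring, so the bearing is indirect. Compound 4 is therefore expected near 55%, between 25% and 85%, an estimated step of a number 3 percentage points lower from compound 3 to compound 4 (within the scatter).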

Compound 4, a percentage reported as inhibition, at one concentration (the size of the read-out at that concentration, not a potency): 43%
Beside the measured number, compound 4's estimate is 12 percentage points above it, within the range that was stated.
By their numbers in this assay, from the lowest: compounds 4, 2 and 3 (each within the scatter of the next, the first and the last beyond it); then compound 1.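

With a ring on this aromatic carbon, the result is a number 15 percentage points lower from compound 3 to compound 4 (beyond the scatter) and a number 42 percentage points lower from compound 1 to compound 4 (beyond the scatter), but only a number 9 percentage points lower from compound 2 to compound 4 (within the scatter), so a group of this size does not separate from plain hydrogen here. Chloro remains the only one of the four groups whose compound stands beyond the scatter of all the others. Nothing available explains these steps.

From the compounds shown here alone, it remains open whether bromo or fluoro would match chloro, and whether a morpholin-4-yl ring or a dimethylamino group would read like 4-methylpiperazin-1-yl.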